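The source may report more compounds than this note shows. Statements on the series, on what has been measured and on what is new or still open speak of the compounds shown alone.

Measured in a functional assay on HeLa cells (Homo sapiens) for inhibition, read by MTT assay, with a stated time of 72 h; on this read-out lower numbers stand for stronger inhibition and higher numbers for weaker inhibition:
Compound 1 `Brc1ccc(-c2nnc(SCCCN3CCN(c4nc5ccccc5s4)CC3)o2)cc1`: 243000 nM
Compound 2 `Oc1ccc(-c2nnc(SCCCN3CCN(c4nc5ccccc5s4)CC3)o2)cc1`: 139000 nM

Within the data shown here, only two numbers are available, and compound 2, at 139000 nM, cannot be separated from compound 1. Among the measured compounds shown here, the one measured step, a 1.7-fold lower number from compound 1 to compound 2 (0.24 log units; within the scatter), lies within the scatter. Compound 3 `O=C(NCc1nnc(SCCCN2CCN(c3nc4ccccc4s3)CC2)o1)c1ccccc1` keeps the shared core, but carries benzamidomethyl in place of 4-hydroxyphenyl on an aromatic carbon of the five-membered aromatic ring with 2 nitrogen and 1 oxygen: benzamidomethyl in place of 4-hydroxyphenyl on an aromatic carbon. The measured step bears on this change only loosely, since it exchanged hydroxy for bromo on an aromatic carbon and left the rest of that group in place. For the measured compounds named here, no measurement yet tests the replacement of the whole group. Going by the values given here, with only that small step as a guide, no shift beyond the scatter is expected in this assay, and no direction can be favoured, though the uncertainty is wide. The expected change is a 1.2-fold higher number from compound 2 to compound 3 (0.06 log units; within the scatter). For compound 3 the estimated value is 160000 nM, with an expected range from 60000 nM to 400000 nM.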

Compound 3, half-maximal inhibitory concentration: 78100 nM
Compound 3: the middle estimate sits 2.0-fold (0.31 log units) above what was measured, within the range that was stated.
By their numbers in this assay, from the lowest: compounds 3, 2 and 1 (each within the scatter of the next, the first and the last beyond it).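

In this assay, the whole 4-hydroxyphenyl group on this aromatic carbon of the five-membered ring could be exchanged for benzamidomethyl, a far larger change than the earlier swap of hydroxy for bromo, and the step is still only a 1.8-fold lower number from compound 2 to compound 3 (0.25 log units; within the scatter). So the ring attached directly at this position can be replaced by a benzene ring carried on an amide-bearing link, with compound 3 and compound 2 remaining inseparable in this read-out. Among these compounds, the same exchange made from the bromo compound gives the first step in the set to clear the scatter, a 3.1-fold lower number from compound 1 to compound 3 (0.49 log units; beyond the scatter), although it is modest and compound 2 lies within the scatter of both neighbours, and nothing available accounts for this difference.

Going by these compounds, it remains open whether an amine or a carboxylic acid on the benzene ring of benzamidomethyl would shift the number beyond the scatter from compound 3. A longer chain between the amide and the five-membered ring is equally untested among the compounds shown, so how far this position tolerates further extension stays unknown.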